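The source may report more compounds than this note shows. Statements on the series, on what has been measured and on what is new or still open speak of the compounds shown alone.

In a functional assay on KBVIN cells (Homo sapiens) for cytotoxicity, read by MTT assay, with a stated time of 72 h (a higher number here means that more compound is needed for the effect, a lower number that less compound is needed), compound 1 `CCc1cccc2c(OC)c(-c3occ(C)c3C(=O)OC)ccc12` gives 1.3 ug/mL. Compound 2 `CCOc1c(-c2occ(C)c2C(=O)O)ccc2c(CC)cccc12` reads > 10 ug/mL, which is a limit and not a number. Compound 3 `CCCOC(=O)c1c(C)coc1-c1ccc2c(CC)cccc2c1OC` reads > 10 ug/mL, also a limit and not a number. For the measured compounds named here, compound 3 is therefore known only from one side, and the series so far shows (the limit of > 10 ug/mL in this assay, at which 2 of the 3 values shown sit).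

The next analogue is compound 4 `CCc1cccc2c(OC)c(-c3occ(C)c3C(=O)NC)ccc12`, and the change from compound 3 is methylamino in place of propoxy on a carbonyl carbon, or propoxycarbonyl to methylcarbamoyl when cut one bond further out.

Going by the values given here, only one measured step bears on this place, and it stays within the esters: an at least 7.6-fold higher number from compound 1 to compound 3 (0.88 log units; beyond the scatter). Among the compounds with values here, no measured pair yet replaces an ester with an amide, so that step is only a loose guide. Compound 4 loses the propoxy group of compound 3, the group that went with an at least 7.6-fold higher number from compound 1 to compound 3 (0.88 log units; beyond the scatter), so a modest move to a lower number is expected in this assay, smaller than that step and uncertain in size. The expected change is an at least 1.2-fold lower number from compound 3 to compound 4 (0.09 log units; that floor lies within the scatter). For compound 4 the estimate is 8 ug/mL, with an expected range of 3 ug/mL to 20 ug/mL. A reading that is again only a limit remains about as likely as a number.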

Compound 4, concentration for half-maximal effect: > 10 ug/mL
Compound 4 ended at the assay's limit; the forecaster's own chance of this, stated with the estimate: 50%; middle value at least 1.2-fold (0.09 log units) from the limit.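

In this assay, the carbonyl carbon now carries a second replacement for the methoxy of compound 1, this time an amide-forming group rather than a longer ester group: methylamino gives an at least 7.6-fold higher number from compound 1 to compound 4 (0.88 log units; beyond the scatter). This has the same printed size as the step for propoxy, an at least 7.6-fold higher number from compound 1 to compound 3 (0.88 log units; beyond the scatter), so at this position compound 1 remains the only one of the three with a number, and each step size is only a floor. The step between compound 3 and compound 4 cannot be read, as both values are limits, and the limit now holds most of the series: the limit of > 10 ug/mL in this assay, at which 3 of the 4 values shown sit.

As far as these compounds go, how far compound 3 and compound 4 lie beyond the limit remains open, so propoxy and methylamino cannot be ranked against each other at this carbonyl carbon. Also open, from the compounds shown here alone, is whether ethoxy, amino or dimethylamino on the same carbon would give a measurable number, and how such a number would compare with compound 1 at 1.3 ug/mL.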